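The source may hold more compounds than are shown below. What is called first, only, known or untested is meant among the compounds shown, and "the series" means these compounds.

Working notes on the series.

Compound 1 `CN(C)c1ccc(/C=C(/SCc2ccc(F)cc2)C(=O)c2ccc(Br)cc2)cc1` and compound 2 `Cc1ccc(S(=O)(=O)/C(=C/c2ccc(N(C)C)cc2)C(=O)c2ccc(Br)cc2)cc1` share one core and differ only at a single point. In a functional assay on DU-145 cells (Homo sapiens) for inhibition, read by trypan blue exclusion, with a stated time of 96 h (a higher number here means a weaker inhibitor of growth, a lower number a stronger inhibitor of growth), compound 2 gives 50000 nM. Compound 1 gives 50000 nM in this assay. The change between them, ((4-fluorobenzyl)sulfanyl in place of (4-methylphenyl)sulfonyl on a double-bonded chain carbon bound to a carbonyl carbon and a double-bonded chain carbon), produces no change at the digits printed from compound 2 to compound 1 (within the scatter).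

Compound 3 `CCOc1ccc(/C=C(\C(=O)c2ccc(Cl)cc2)S(=O)(=O)c2ccc(C)cc2)cc1OC` carries a different core, and the difference between the two cores is not broken down here. In this assay compound 3 gives 1000 nM, the lowest number of the three measured compounds, and its distance to both compound 1 and compound 2 is beyond the scatter.

Compound 4 `CCOc1ccc(/C=C(/SCc2ccc(F)cc2)C(=O)c2ccc(Cl)cc2)cc1OC` is not yet measured. It stands to compound 3 as compound 1 stands to compound 2: the difference is (4-fluorobenzyl)sulfanyl in place of (4-methylphenyl)sulfonyl on a double-bonded chain carbon bound to a carbonyl carbon and a double-bonded chain carbon, with the place of the change identical in both pairs, so this is the same change made on the core of compound 3.

Among the measured compounds shown here, the only precedent for this change is the step from compound 2 to compound 1, which was no change at the digits printed from compound 2 to compound 1 (within the scatter). That precedent is read with caution, since both compound 1 and compound 2 sit at the same high number and the change may have gone unseen there. The expectation is that the change on the core of compound 3 will again move the number little, with a 2.5-fold higher number from compound 3 to compound 4 (0.40 log units; beyond the scatter) as the estimated step, because of no change at the digits printed from compound 2 to compound 1 (within the scatter). Compound 4 is therefore expected to give about 2500 nM in this assay, with an estimated range from 600 nM to 15000 nM.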

Compound 4, concentration for 50% growth inhibition: 1000 nM
Compound 4: middle estimate off by 2.5-fold (0.40 log units), on the high side, within the range that was stated.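

In this assay, placing (4-fluorobenzyl)sulfanyl in place of (4-methylphenyl)sulfonyl on a double-bonded chain carbon bound to a carbonyl carbon and a double-bonded chain carbon gives no change at the digits printed from compound 3 to compound 4 (within the scatter), and the comparison with the earlier step shows agreement between the two cores: the same change on two cores in this assay, no change at the digits printed (within the scatter) from compound 2 to compound 1 and no change at the digits printed (within the scatter) from compound 3 to compound 4, 1.0-fold (0.00 log units) apart, within the scatter of two such steps

The change therefore carries over between the core of compound 1 and the core of compound 3, and the step on the core of compound 3 adds a case where compound 4 gives 1000 nM, well away from the high number shared by the first pair. This shows transfer across two cores in one cell assay only; it does not show that the two groups are interchangeable on other cores or in other read-outs, and since each group is exchanged whole, the sulfonyl and sulfanyl links cannot be separated from the aromatic rings they carry.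

Going by these compounds, it remains open whether an amine or a carboxylic acid at the same place on the double-bonded chain carbon would also leave the number unmoved. On these data alone, it also remains open whether a longer chain between the sulfur and the aromatic ring would do the same on either core.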